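Swapping the Basic Tail of a Urea-Linked Series

A few compounds are considered here, and "the series" means these few. Any claim that something is new, unique, unknown or untested is made for them only; others in the source may bear on it.

Of the compounds shown here, three sharing one core have been tested in a functional assay on A549 cells (Homo sapiens) for antiproliferative activity, read by MTT assay, with a stated time of 72 h; a lower number here means a stronger inhibitor, a higher number a weaker inhibitor. Compound 1 `COc1cc2c(Oc3c(F)cc(NC(=O)NN4C(=O)C(C)SC4c4c(F)cccc4F)cc3F)ccnc2cc1OCCCN1CCCC1` gives 830 nM in this assay. Compound 2 `COc1cc2c(Oc3c(F)cc(NC(=O)NN4C(=O)C(C)(C)SC4c4c(F)cccc4F)cc3F)ccnc2cc1OCCCN1CCCC1` gives 1450 nM. Within the data shown here, the step of a 1.7-fold higher number from compound 1 to compound 2 (0.24 log units; within the scatter) is the only one-change comparison among the three. Compound 3 `CCN1CCN(CCCOc2cc3nccc(Oc4c(F)cc(NC(=O)NN5C(=O)CSC5c5c(F)cccc5F)cc4F)c3cc2OC)CC1` gives 350 nM, the lowest of the three numbers, and its gaps to compound 1 and to compound 2 both lie beyond the scatter. Among the measured compounds shown here, compound 3 differs from compound 1 in two places at once, so no single step between them can be read.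

Compound 4 `COc1cc2c(Oc3c(F)cc(NC(=O)NN4C(=O)CSC4c4c(F)cccc4F)cc3F)ccnc2cc1OCCCN1CCC(N2CCCCC2)CC1` has not yet been measured. It differs from compound 3 by 4-(piperidin-1-yl)piperidin-1-yl in place of 4-ethylpiperazin-1-yl on a saturated chain carbon, three bonds along the chain from an oxygen on an aromatic ring. For the measured compounds named here, no measured step touches this part of the molecule: the only single-change step among the three measured compounds concerns a methyl on a saturated ring carbon and lies within the scatter. Nothing is therefore known about how the tail itself moves the number. The expectation for compound 4 is a step of a 1.1-fold higher number from compound 3 to compound 4 (0.06 log units; within the scatter) that stays within the scatter. Compound 4 is estimated at 400 nM, with a range from 150 nM to 1100 nM.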

Compound 4, half-maximal inhibitory concentration: 380 nM
For compound 4 the middle estimate is 1.1-fold (0.02 log units) above the measured one, and the stated range covers the measured number.
By their numbers in this assay, from the lowest: compounds 3 and 4 (each within the scatter of the next); then compounds 1 and 2 (each within the scatter of the next).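

Among these compounds, putting 4-(piperidin-1-yl)piperidin-1-yl in place of 4-ethylpiperazin-1-yl on a saturated chain carbon, three bonds along the chain from an oxygen on an aromatic ring, gives a 1.1-fold higher number from compound 3 to compound 4 (0.04 log units; within the scatter) in this assay and provides the first single-change reading at this position. The tail that enters has 12 heavy atoms against 8 and two six-membered non-aromatic rings against one, yet the two tails cannot be told apart in this assay, so on this core this change in the tail leaves the number within the scatter. No evidence is at hand to account for this result.

On these data alone, compounds 1 and 2 differ from compound 3 and compound 4 in more than one place, so those steps cannot be read, and it remains open whether the same tail change would also stay within the scatter on a core carrying a methyl on the saturated ring carbon. As far as these compounds go, it is also open whether a morpholine ring, a dimethylamino group or a longer chain at this position would keep the number within the scatter of these two compounds.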